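From Trifluoromethyl to Pyrrolidinylcarbonyl on the Shared Core

The source may hold more compounds than are shown below. What is called first, only, known or untested is meant among the compounds shown, and "the series" means these compounds.

Three compounds share one core and differ only in the aryl group on a nitrogen on an aromatic ring. In a functional assay on A549 cells (Homo sapiens) for antiproliferative activity, read by MTT assay, with a stated time of 72 h (on this read-out lower numbers stand for stronger inhibition and higher numbers for weaker inhibition), compound 1 `CN1CCN(Cc2ccc(NC(=O)Nc3ccc4ncnc(Nc5ccc(F)c(Cl)c5)c4c3)cc2)CC1` gives 3480 nM, compound 2 `COc1ccc(Nc2ncnc3ccc(NC(=O)Nc4ccc(CN5CCN(C)CC5)cc4)cc23)cc1Cl` gives 3570 nM, and compound 3 `CN1CCN(Cc2ccc(NC(=O)Nc3ccc4ncnc(Nc5cccc(C(F)(F)F)c5)c4c3)cc2)CC1` gives 1650 nM, the lowest of the three numbers. The steps of a 2.1-fold lower number from compound 1 to compound 3 (0.32 log units; beyond the scatter) and a 2.2-fold lower number from compound 2 to compound 3 (0.34 log units; beyond the scatter) were modest, while a 1.0-fold higher number from compound 1 to compound 2 (0.01 log units; within the scatter) stayed within the scatter. Compound 4 `CN1CCN(Cc2ccc(NC(=O)Nc3ccc4ncnc(Nc5cccc(C(=O)N6CCCC6)c5)c4c3)cc2)CC1` carries (pyrrolidin-1-yl)carbonyl in place of trifluoromethyl on an aromatic carbon. Going by the values given here, no measured step changes this position in this way, so the earlier steps give only a sense of scale: changes on this ring have so far moved this assay by modest amounts. Compound 4 is therefore expected to give 2500 nM, with a range from 800 nM to 8000 nM. The step of a 1.5-fold higher number from compound 3 to compound 4 (0.18 log units; within the scatter) is estimated to be small, its direction uncertain.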

Compound 4, half-maximal inhibitory concentration: > 10000 nM
Compound 4: only a limit was reported (the forecaster's own chance of this, stated with the estimate: 5%); at least 4.0-fold (0.60 log units) between middle value and limit.
By their numbers in this assay, from the lowest: compound 3; then compounds 1 and 2 (each within the scatter of the next). At a limit, above all of these: compound 4.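

In this assay, putting (pyrrolidin-1-yl)carbonyl in place of trifluoromethyl on this aromatic carbon gives an at least 6.0-fold higher number from compound 3 to compound 4 (0.78 log units; beyond the scatter), so changes on this ring do not always stay modest, as the earlier aryl swaps had suggested. Compound 4 reaches only a limit of the assay, not a number: the limit of > 10000 nM in this assay, at which 1 of the 4 values shown sits.

From the compounds shown here alone, the full size of this step therefore stays unknown, as does whether the carbonyl or the pyrrolidine ring accounts for it. Also open, going by these compounds, is how a nitrile, a carboxylic acid or a simple amine on this carbon would read in this assay.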